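The source may report more compounds than this note shows. Statements on the series, on what has been measured and on what is new or still open speak of the compounds shown alone.

The measured compounds are:
- compound 1, `CN(C)/C=C/N1CCN(CC(=O)Nc2ccc(-c3nc(-c4ccccc4)c(-c4ccccc4)n3C)cc2)CC1`, which in a functional assay on HT-29 cells (Homo sapiens) for cytotoxicity, read by MTT assay, with a stated time of 24 h, tested at 32 ug/mL (a lower number here means a weaker effect, a higher number a stronger effect of the compound at the concentration tested), gives 29.8%
- compound 2, `Cn1c(-c2ccc(NC(=O)CN3CCN(Cc4ccccc4)CC3)cc2)nc(-c2ccccc2)c1-c1ccccc1`, which in this assay gives 40%

Compound 2 stands highest of these two numbers. Going by the values given here, its nearest neighbour is compound 1, and the single measured step, a number 10.2 percentage points higher from compound 1 to compound 2 (beyond the scatter), lies beyond the scatter; it exchanges one group on an amine nitrogen in a ring for another. Compound 3, `COc1ccc(CN2CCN(CC(=O)Nc3ccc(-c4nc(-c5ccccc5)c(-c5ccccc5)n4C)cc3)CC2)cc1`, is not yet measured. It differs from compound 2 in one place: methoxy in place of hydrogen on an aromatic carbon. Among the compounds with values here, the group that enters is added to the benzyl already present rather than replacing it, and no measured step shows what such an addition does here. The step from compound 1 to compound 2 concerns a different exchange at the same ring nitrogen and does not bear on a methoxy on the benzyl. With no guide from the data, compound 3 is expected to stay close to compound 2. The expected step, no change at the digits printed from compound 2 to compound 3 (within the scatter), is therefore none beyond the scatter. The estimate for compound 3 in this assay is 40%, with a range from 25% to 55%.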

Compound 3, a percentage reported as activity, at one concentration (the size of the read-out at that concentration, not a potency): 29.9%
Beside the measured number, compound 3's estimate is 10.1 percentage points above it; measured number inside the range.
By their numbers in this assay, from the lowest: compounds 1 and 3 (each within the scatter of the next); then compound 2.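

In this assay, adding a methoxy to the benzyl ring gives a number 10.1 percentage points lower from compound 2 to compound 3 (beyond the scatter) as the result, so a change at the far end of this benzyl group can alter the read-out and not only an exchange of the whole group on the ring nitrogen. The 4-methoxybenzyl group also no longer stands apart from 2-(dimethylamino)ethenyl at that nitrogen, since the comparison gives a number 0.1 percentage points higher from compound 1 to compound 3 (within the scatter) and the two groups cannot be told apart in this read-out, even though the plain benzyl could be. No measurement of any property of these compounds is available to account for the effect of the methoxy.

As far as these compounds go, with only one substituent on the benzyl ring, it remains open whether this result is specific to methoxy or would also appear with a fluorine, a hydroxyl or a methyl in the same place. From the compounds shown here alone, it is equally open how a methoxy would behave at another ring position, or whether a longer chain between the ring nitrogen and the phenyl ring would change the picture.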